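Removing the aryl group from the oxazole of a fatty-acid amide hydrolase inhibitor

This account rests on a few compounds, and the source may have more. Where it says the series, first, only, none or still open, it means among the compounds named here.

Three compounds share one core and differ only in the group carried on an aromatic carbon of the five-membered ring. In an assay (Rattus norvegicus) for inhibition of Fatty-acid amide hydrolase 1 (Homo sapiens) (a lower number here means a stronger inhibitor, a higher number a weaker inhibitor), compound 1 `O=C(CCCCCCc1ccccc1)c1ncc(-c2ccc(F)cc2)o1` gives 62 nM and compound 2 `COc1ccc(-c2cnc(C(=O)CCCCCCc3ccccc3)o2)cc1` gives 100 nM; the step of a 1.6-fold higher number from compound 1 to compound 2 (0.21 log units; within the scatter) is small. Compound 3 `COc1ccnc(-c2cnc(C(=O)CCCCCCc3ccccc3)o2)c1` gives 0.8 nM, the lowest of the three numbers, reached through a 78-fold lower number from compound 1 to compound 3 (1.89 log units; beyond the scatter) and a 130-fold lower number from compound 2 to compound 3 (2.10 log units; beyond the scatter). Compound 4 `O=C(CCCCCCc1ccccc1)c1ncc(Cl)o1` carries the change (chloro in place of 4-methoxypyridin-2-yl on an aromatic carbon). Both large steps show that the group at this place governs the number, and the whole ring now leaves, so a large rise is expected, a 380-fold higher number from compound 3 to compound 4 (2.57 log units; beyond the scatter). Compound 4 is therefore estimated at 300 nM, within 60 nM to 2000 nM.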

Compound 4, inhibition constant: 5 nM
Compound 4: the middle estimate sits 60-fold (1.78 log units) above what was measured; measured number below the stated range.
By their numbers in this assay, from the lowest: compound 3; then compound 4; then compounds 1 and 2 (each within the scatter of the next).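

In this assay a full aromatic ring is not needed at this position for a low number, since a single chloro costs only a 6.3-fold higher number from compound 3 to compound 4 (0.80 log units; beyond the scatter) and gains a 12-fold lower number from compound 1 to compound 4 (1.09 log units; beyond the scatter) as well as a 20-fold lower number from compound 2 to compound 4 (1.30 log units; beyond the scatter) over the two phenyl-bearing compounds. Among the groups shown, only 4-methoxypyridin-2-yl gives a lower number than chloro. No measured evidence explains this order. The compounds shown leave open whether bromo, methyl or a bare hydrogen on this carbon would stay near compound 4, and whether pyridin-2-yl without its methoxy would stay near compound 3.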